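Replacing furan-3-yl with 2-phenylethenyl on the shared core

The compounds below may be only part of what the source reports. "The series", "measured", "known", "first", "only" and "open" are said of these compounds alone.

Of the compounds shown here, two with the same core have been measured so far in a functional assay on CAPAN-1 cells (Homo sapiens) for antiproliferative activity, with a stated time of 72 h; a lower number here means a stronger inhibitor, a higher number a weaker inhibitor. Compound 1 `Nc1ncnn2c([C@@H]3O[C@H](CO)[C@@H](O)[C@H]3O)cc(C#Cc3ccc(F)cc3)c12` gives 55400 nM, while compound 2 `Nc1ncnn2c([C@@H]3O[C@H](CO)[C@@H](O)[C@H]3O)cc(-c3ccoc3)c12` gives 900 nM, the lower of the two numbers and so the stronger inhibitor of the pair. Still unmeasured is compound 3 `Nc1ncnn2c([C@@H]3O[C@H](CO)[C@@H](O)[C@H]3O)cc(/C=C/c3ccccc3)c12`, which keeps the core and changes one group of compound 2: 2-phenylethenyl in place of furan-3-yl on an aromatic carbon.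

For the measured compounds named here, only one measured step bears on this change. That step, a 62-fold lower number from compound 1 to compound 2 (1.79 log units; beyond the scatter), was large and came with furan-3-yl in place of 2-(4-fluorophenyl)ethynyl on an aromatic carbon. Like that group of compound 1, the 2-phenylethenyl group of compound 3 carries a six-membered aromatic ring of carbon only, so a move back toward the higher number seems likely. Going by the values given here, one pair is thin evidence, however, and no measured compound carries this exact group. The expected change is a 10-fold higher number from compound 2 to compound 3 (1.00 log units; beyond the scatter), a clear step toward weaker inhibition. For compound 3 the estimated value is 9000 nM, with an expected range of 1500 nM to 50000 nM.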

Compound 3, half-maximal inhibitory concentration: 2600 nM
Compound 3: middle estimate off by 3.5-fold (0.54 log units), on the high side, and the stated range covers the measured number.
By their numbers in this assay, from the lowest: compound 2; then compound 3; then compound 1.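

In this assay, the step of a 2.9-fold higher number from compound 2 to compound 3 (0.46 log units; beyond the scatter) shows that this position, two ring bonds from the ring nitrogen, can take the larger 2-phenylethenyl group at only a modest cost. The step of a 21-fold lower number from compound 1 to compound 3 (1.33 log units; beyond the scatter) adds something the first pair could not show: compound 1 and compound 3 both carry a six-membered aromatic ring of carbon only, yet they lie far apart, so that ring alone does not set the number here. The two groups differ in both the link to the ring, a double bond in compound 3 and a triple bond in compound 1, and the fluorine on the ring of compound 1, and nothing shown gives a measured reason for either step.

Those two differences travel together, so 2-phenylethynyl and 2-(4-fluorophenyl)ethenyl would be the groups needed to tell which one accounts for the large step. From the compounds shown here alone, it also remains open how a plain phenyl group, joined directly to the aromatic carbon with no link, would compare with furan-3-yl at this position.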